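The compounds below may be only part of what the source reports. "The series", "measured", "known", "first", "only" and "open" are said of these compounds alone.

Compound 1, `CC(=O)O[C@H]1C=CC(=O)O[C@@H]1c1nc(-c2ccccc2)oc1-c1ccccc1`: in a functional assay on SMMC-7721 cells (Homo sapiens) for cytotoxicity, read by MTT assay, with a stated time of 48 h (on this read-out lower numbers stand for stronger inhibition and higher numbers for weaker inhibition), compound 1 gives 15700 nM.
Compound 2, `CC(=O)O[C@H]1C=CC(=O)O[C@H]1[C@H]1OC(C)(C)O[C@@H]1c1ccccc1`: in this assay compound 2 gives > 40000 nM, which is a limit of the assay and not a number.

Among the compounds with values here, compound 1 stands as the only measured number in this assay; the other value shown is a limit, namely (the limit of > 40000 nM in this assay, at which 1 of the 2 values shown sits). Within the data shown here, no pair of measured compounds differs in a single place, so no measured step is available to size the change to come.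

Compound 3, `C/C=C\c1nc([C@H]2OC(=O)C=C[C@@H]2OC(C)=O)c(-c2ccccc2)o1`, has not yet been measured in this assay. It differs from compound 1 by prop-1-en-1-yl in place of phenyl on an aromatic carbon. Compound 1 and compound 3 share the same core, and the change sits on the five-membered aromatic ring described above.

Among the measured compounds shown here, with no measured step as guidance, compound 3 is expected to land close to compound 1, with the step of a 1.6-fold higher number from compound 1 to compound 3 (0.20 log units; within the scatter) estimated to fall within the usual scatter or somewhat toward weaker inhibition. Compound 3 is therefore estimated at 25000 nM, within a range of 8000 nM to 80000 nM.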

Compound 3, half-maximal inhibitory concentration: > 40000 nM
Compound 3: only a limit was reported (the forecaster's own chance of this, stated with the estimate: 35%); middle value at least 1.6-fold (0.20 log units) from the limit.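

In this assay, within the data shown here, the first measured change at this position, on the aromatic carbon next to the ring nitrogen and next to the ring oxygen, is an at least 2.5-fold higher number from compound 1 to compound 3 (0.40 log units; beyond the scatter). This shows that the position is not indifferent to its substituent: with prop-1-en-1-yl in place of phenyl, the inhibition seen for compound 1 is not kept, and the change lies beyond the scatter. Compound 3 rests at a limit of the assay and not at a number, so the step gives only the smallest possible size of the change, and the true size cannot be read because the value falls at the assay's ceiling: the limit of > 40000 nM in this assay, at which 2 of the 3 values shown sit.

The compounds shown leave open whether the loss follows from removing the six-membered aromatic ring or from the swap to a shorter chain with a double bond, since the one change does both at once. From the compounds shown here alone, whether a substituted phenyl, a pyridine ring, a saturated propyl chain or an amine on this carbon would match or better compound 1 also remains open.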